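This account rests on a few compounds, and the source may have more. Where it says the series, first, only, none or still open, it means among the compounds named here.

Measured in a functional assay on Kasumi 1 cells (Homo sapiens) for inhibition, read by WST assay, with a stated time of 4 days; a lower number here means a stronger inhibitor, a higher number a weaker inhibitor:
- compound 1 `CC(C)(C)c1ccc(CN2CCN(S(=O)(=O)Nc3ccc(SCCc4ccccc4)cc3C(=O)O)CC2)cc1`: 20300 nM
- compound 2 `CCC(=O)N1CCN(c2c3ccc(-c4cccc(F)c4)cc3nn2Cc2ccccc2)CC1`: 7100 nM

Of these two, compound 2 has the lower number, 7100 nM, and compound 1 gives 20300 nM. The gap between these two values lies beyond the scatter. Compound 3 `C=CC(=O)N1CCN(c2c3ccc(-c4cccc(F)c4)cc3nn2Cc2ccccc2)CC1` keeps the core of compound 2 and alters one group: vinyl in place of ethyl on a carbonyl carbon. Vinyl takes the place of ethyl on a carbonyl carbon, so that propanoyl becomes vinylcarbonyl. Among the compounds with values here, no measured pair of compounds shows this change, so the data offer no direct precedent for it. In this assay, a moderate step towards a lower number, beyond the scatter, is nevertheless expected, with wide uncertainty. The expected change is a 2.8-fold lower number from compound 2 to compound 3 (0.45 log units; beyond the scatter). The estimated value for compound 3 is 2500 nM, within an expected range of 500 nM to 10000 nM.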

Compound 3, half-maximal inhibitory concentration: 5500 nM
Beside the measured number, compound 3's estimate is 2.2-fold (0.34 log units) below it; measured number inside the range.
By their numbers in this assay, from the lowest: compounds 3 and 2 (each within the scatter of the next); then compound 1.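

In this assay, vinyl in place of ethyl on a carbonyl carbon gives a 1.3-fold lower number from compound 2 to compound 3 (0.11 log units; within the scatter), so this first direct comparison at the position does not separate the two groups. The change adds one double bond outside aromatic rings and keeps the count of heavy atoms, yet on this shared core it brings no shift beyond the scatter. Nothing available here speaks to the reason for this outcome.

Going by these compounds, it remains open whether a longer chain, an amine or a carboxylic acid on that carbonyl carbon would move the number beyond the scatter in this assay. On these data alone, it is also open whether the same exchange of ethyl for vinyl would give a similar step on another core or in a different kind of test.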